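Adding a second methoxy: compound 3 to compound 4

This account rests on a few compounds, and the source may have more. Where it says the series, first, only, none or still open, it means among the compounds named here.

Values in an ADME assay on BHK-21 cells (Mesocricetus auratus) for cytotoxicity, read by MTT assay (on this read-out lower numbers stand for higher toxicity in this test and higher numbers for lower toxicity in this test), so far:
- compound 1 `C/C(=N\NC(N)=O)c1ccc2c(c1)nc(-c1ccc(Cl)cc1)n2C1CCCCC1` reads > 100000 nM
- compound 2 `C/C(=N\NC(N)=O)c1ccc2c(c1)nc(-c1ccc(C(F)(F)F)cc1)n2C1CCCCC1` reads > 100000 nM
- compound 3 `COc1ccc(-c2nc3cc(/C(C)=N/NC(N)=O)ccc3n2C2CCCCC2)cc1` reads "not determined" (no result reported)

Compound 1 has the entry > 100000 nM, which is a limit and not a number. Compound 2 has the entry > 100000 nM, which is likewise a limit. Compound 3 has no number of its own ("not determined" (no result reported)), and the only frame around it is the limit of > 100000 nM in this assay, at which 2 of the 3 values shown sit, in the series. Compound 4 `COc1ccc(-c2nc3cc(/C(C)=N/NC(N)=O)ccc3n2C2CCCCC2)c(OC)c1` differs from compound 3 by one change (methoxy in place of hydrogen on an aromatic carbon), which turns 4-methoxyphenyl into 2,4-dimethoxyphenyl. Among the measured compounds shown here, with a step that the two limits leave unreadable from compound 1 to compound 2 as the only measured step, no size can be carried over, so in this assay no step beyond the usual scatter is expected and no direction is assumed. Compound 4 is estimated at 120000 nM (expected range 50000 nM to 300000 nM), most likely reported as a limit again.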

Compound 4, half-maximal cytotoxic concentration: 19000 nM
Beside the measured number, compound 4's estimate is 6.3-fold (0.80 log units) above it; the whole stated range lies above it.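

In this assay compound 4 is the first compound shown with a number rather than a limit, and the other two readings stay at that limit: the limit of > 100000 nM in this assay, at which 2 of the 4 values shown sit.

The aromatic ring on the shared core is therefore a place where the read-out can move: 2,4-dimethoxyphenyl gives an at least 5.2-fold lower number from compound 2 to compound 4 (0.72 log units; beyond the scatter), and an at least 5.2-fold lower number from compound 1 to compound 4 (0.72 log units; beyond the scatter).

Steps resting on two limits or on the missing result of compound 3 cannot be read, so the share of the added methoxy alone stays unknown. Going by these compounds, whether an amine or a carboxylic acid ortho to a large group would move the read-out likewise stays open.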